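Methyl on the amine nitrogen across two cores

The source may hold more compounds than are shown below. What is called first, only, known or untested is meant among the compounds shown, and "the series" means these compounds.

Compound 1 `CC[C@H](N)C(=O)N[C@@H]1C(=O)N2[C@@H](CC[C@@H]1CCN)CC[C@H]2C(=O)NC(c1ccccc1)c1ccccc1` is the reference point. In a functional assay on HL-60 cells (Homo sapiens) for cytotoxicity, read by MTT assay, with a stated time of 96 h (on this read-out lower numbers stand for stronger inhibition and higher numbers for weaker inhibition), compound 1 gives 25000 nM. Compound 2 `CC[C@H](NC)C(=O)N[C@@H]1C(=O)N2[C@@H](CC[C@@H]1CCN)CC[C@H]2C(=O)NC(c1ccccc1)c1ccccc1` carries methyl in place of hydrogen on an amine nitrogen; in this assay compound 2 gives 31000 nM, and the step is a 1.2-fold higher number from compound 1 to compound 2 (0.09 log units; within the scatter). Compound 3 `CC[C@H](N)C(=O)N[C@@H]1C(=O)N2[C@@H](CC[C@@H]1CCNC(=O)NCc1ccccc1)CC[C@H]2C(=O)NC(c1ccccc1)c1ccccc1` carries benzylcarbamoyl in place of hydrogen on an amine nitrogen; in this assay compound 3 gives 83300 nM, a step of a 3.3-fold higher number from compound 1 to compound 3 (0.52 log units; beyond the scatter), which leaves compound 3 with the highest number of the three measured.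

Compound 4 `CC[C@H](NC)C(=O)N[C@@H]1C(=O)N2[C@@H](CC[C@@H]1CCNC(=O)NCc1ccccc1)CC[C@H]2C(=O)NC(c1ccccc1)c1ccccc1` is not yet measured. Relative to compound 3 it carries methyl in place of hydrogen on an amine nitrogen, the same change as that from compound 1 to compound 2, with the place described in identical words in both cases. The two cores differ as already described for compound 3 against compound 1. Among the compounds with values here, the one measured instance of this change, a 1.2-fold higher number from compound 1 to compound 2 (0.09 log units; within the scatter), moved the number only within the scatter, so a comparable outcome is expected on the core of compound 3. The step in this assay is estimated at a 1.2-fold higher number from compound 3 to compound 4 (0.08 log units; within the scatter), resting on compound 1 and compound 2 with a 1.2-fold higher number from compound 1 to compound 2 (0.09 log units; within the scatter). Compound 4 is therefore expected to give about 100000 nM in this assay, between 45000 nM and 220000 nM.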

Compound 4, half-maximal inhibitory concentration: 52200 nM
Compound 4: the middle estimate sits 1.9-fold (0.28 log units) above what was measured, and the stated range covers the measured number.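

In this assay, methyl in place of hydrogen on an amine nitrogen gives a 1.6-fold lower number from compound 3 to compound 4 (0.20 log units; within the scatter), and this step does not differ from the earlier one on the core of compound 1 by more than two such steps scatter: the same change on two cores in this assay, a 1.2-fold higher number (0.09 log units; within the scatter) from compound 1 to compound 2 and a 1.6-fold lower number (0.20 log units; within the scatter) from compound 3 to compound 4, 2.0-fold (0.30 log units) apart, within the scatter of two such steps

The benzylcarbamoyl change, read on the methylamino partners, gives a 1.7-fold higher number from compound 2 to compound 4 (0.23 log units; within the scatter), and it also stays close to its earlier counterpart: the same change on two cores in this assay, a 3.3-fold higher number (0.52 log units; beyond the scatter) from compound 1 to compound 3 and a 1.7-fold higher number (0.23 log units; within the scatter) from compound 2 to compound 4, 2.0-fold (0.30 log units) apart, within the scatter of two such steps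

Within these four compounds, then, each change carries from one core to the other without a difference that can be told from the scatter, but each comparison rests on a single pair of steps in one cell assay and does not show that this transfer holds beyond the compounds shown.

Open, from the compounds shown here alone, is whether ethyl or a longer chain on the same amine nitrogen would follow the methyl result. Also open, going by these compounds, is whether acetyl or another acyl group in place of benzylcarbamoyl would carry between the two cores in the same way.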